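Adding a Chloro Group to an Aminothiophene Piperazine

This account rests on a few compounds, and the source may have more. Where it says the series, first, only, none or still open, it means among the compounds named here.

Compound 1 `Nc1scc(CN2CCN(c3ccc(Cl)cc3F)CC2)c1C(=O)c1ccc(Cl)cc1` and compound 2 `Nc1scc(CN2CCN(c3cccc(C(F)(F)F)c3)CC2)c1C(=O)c1ccc(Cl)cc1` share the same core and differ only in the aryl group on the piperazine nitrogen. In an assay on CHO cells for displacement of a labelled ligand from adenosine receptor A1 (Homo sapiens), read by scintillation counting, with a stated time of 120 min, tested at 10 uM (on this read-out higher numbers stand for more inhibition at the one concentration tested (going by the name of the read-out) and lower numbers for less inhibition), compound 1 gives 0%, and in this assay compound 2 gives 0%. The step of no change at the digits printed from compound 1 to compound 2 (within the scatter) shows that exchanging the whole aryl group left the read-out unchanged, so compound 2 stands level with compound 1 at the floor of this assay.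

Compound 3 `Nc1scc(CN2CCN(c3ccc(Cl)c(C(F)(F)F)c3)CC2)c1C(=O)c1ccc(Cl)cc1` differs from compound 2 by chloro in place of hydrogen on an aromatic carbon. Going by the values given here, the only measured step that bears on this, no change at the digits printed from compound 1 to compound 2 (within the scatter), involved a much larger change of the aryl group and produced no change within the scatter, so a single added chloro group is expected to produce no step beyond the scatter either. Compound 3 is therefore expected to give 0% in this assay, with a range from -8% to 12%, the expected step being no change at the digits printed from compound 2 to compound 3 (within the scatter).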

Compound 3, a percentage reported as inhibition, at one concentration (the size of the read-out at that concentration, not a potency): 0%
Beside the measured number, compound 3's estimate shows no gap at the digits printed; measured number inside the range.
By their numbers in this assay, from the lowest: compounds 1, 2 and 3 (each within the scatter of the next).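

In this assay, chloro on the aromatic carbon ortho to a trifluoromethyl group and para to a large group gives no change at the digits printed from compound 2 to compound 3 (within the scatter), the first step shown that changes this one position alone. With 4-chloro-3-(trifluoromethyl)phenyl in place of 4-chloro-2-fluorophenyl, the read-out shows no change at the digits printed from compound 1 to compound 3 (within the scatter), so the three aryl groups shown cannot be told apart in this read-out, and compound 3 gives 0%. Nothing measured here offers an explanation for this flat result.

Going by these compounds, whether an amine or a carboxylic acid on the same aromatic carbon would give a read-out different from that of compound 3 remains open. With all three compounds at the same value, the shown data also leave open what chloro does at this position in any compound with a read-out above that value.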